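Aryl ketone thioethers: removing the fluoro substituent

A few compounds are considered here, and "the series" means these few. Any claim that something is new, unique, unknown or untested is made for them only; others in the source may bear on it.

Measured so far in a functional assay on HT-29 cells (Homo sapiens) for inhibition, read by WST assay, with a stated time of 48 h; a higher number here means a weaker inhibitor, a lower number a stronger inhibitor:
- compound 1 `Cc1ccc(C(=O)CSc2nc3ccccc3[nH]2)cc1` gives 34500 nM
- compound 2 `COc1ccccc1C(=O)CSc1nc2ccccc2[nH]1` gives 36100 nM
- compound 3 `O=C(CSc1nc2ccccc2[nH]1)c1ccc(F)cc1` gives 78700 nM

Compound 3 stands highest of the three numbers in this assay, beyond the scatter from both others; compound 2 is the nearer and compound 1 the further of the two, and all three sit in the weak range.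

Compound 4 `O=C(CSc1nc2ccccc2[nH]1)c1ccccc1` is not yet measured. It differs from compound 3 by hydrogen in place of fluoro on an aromatic carbon. For the measured compounds named here, the only measured step that bears on this position is a 2.3-fold higher number from compound 1 to compound 3 (0.36 log units; beyond the scatter), which tells that swapping between two small groups on this carbon moved the number modestly. Going by the values given here, nothing measured shows what removing the substituent altogether does, and the one bearing step gives no direction for a change to hydrogen. The expectation for compound 4 in this assay is therefore a step of about a 1.3-fold lower number from compound 3 to compound 4 (0.12 log units; within the scatter), at most modest and possibly within the scatter.

Compound 4 is expected to give about 60000 nM in this assay, with a range from 25000 nM to 140000 nM.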

Compound 4, half-maximal inhibitory concentration: 38500 nM
The estimate for compound 4 lay 1.6-fold (0.19 log units) above the measured number, within the range that was stated.
By their numbers in this assay, from the lowest: compounds 1, 2 and 4 (each within the scatter of the next); then compound 3.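

In this assay the change from fluoro to hydrogen on this aromatic carbon now has a direction: a 2.0-fold lower number from compound 3 to compound 4 (0.31 log units; beyond the scatter) is a modest step, and hydrogen carries the lower number. Hydrogen in place of methyl gives a 1.1-fold higher number from compound 1 to compound 4 (0.05 log units; within the scatter) and hydrogen in place of methoxy gives a 1.1-fold higher number from compound 2 to compound 4 (0.03 log units; within the scatter), so compound 1, compound 2 and compound 4 cannot be told apart, and among these four compounds only compound 3, the fluoro compound, stands apart from the rest. Nothing on hand gives a reason for the fluoro step.

Still open, going by these compounds, is whether the higher number belongs to fluoro alone or also comes with chloro or bromo on this carbon, and whether an amine or a carboxylic acid there would move the number in either direction. All four compounds sit in the weak range, and those shown do not tell whether any group on this carbon can bring the number well below that of compound 4.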